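Changing the ring on the sulfonyl sulfur: compound 2 to compound 4

The compounds below may be only part of what the source reports. "The series", "measured", "known", "first", "only" and "open" are said of these compounds alone.

Three compounds have been measured in an ADME assay on microsomes from liver (Homo sapiens) for metabolic stability, tested at 2.5 uM; a lower number here means slower removal, a higher number faster removal of the compound:

Compound 1 `O=S(=O)(c1ccc(F)c(Cl)c1)c1cnc2cc(F)ccc2c1-c1cccc(Cl)c1` gives 0.66 mL/min.
Compound 2 `COc1ccc(-c2c(S(=O)(=O)c3cc(F)cc(F)c3)cnc3cc(F)ccc23)cc1` gives 1.51 mL/min.
Compound 3 `COc1cccc(-c2c(S(=O)(=O)c3cc(F)cc(F)c3)cnc3cc(F)ccc23)c1` gives 1.81 mL/min.

Within this small set, compound 2 stands second highest of the three numbers. For the measured compounds named here, its nearest neighbour is compound 3, reached by the one recorded step a 1.2-fold higher number from compound 2 to compound 3 (0.08 log units; within the scatter), which changes only the ring attached to the shared core. Going by the values given here, the lowest number belongs to compound 1, whose value and that of compound 2 lie apart by more than the usual scatter; compound 1 differs from compound 2 in two places at once, so no single step connects them.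

Compound 4 `COc1ccc(-c2c(S(=O)(=O)c3ccc(F)c(Cl)c3)cnc3cc(F)ccc23)cc1` is not yet measured. It keeps the 4-methoxyphenyl of compound 2 and alters the group on the sulfonyl sulfur: 3-chloro-4-fluorophenyl in place of 3,5-difluorophenyl on a sulfonyl sulfur. Among the compounds with values here, no recorded step changes this position in isolation, so there is no direct precedent. Within the data shown here, the only measured step, from compound 2 to compound 3, touched a different ring and stayed within the scatter. With nothing pointing clearly either way, the expectation for compound 4 in this assay is a step no larger than the scatter, a 1.3-fold lower number from compound 2 to compound 4 (0.10 log units; within the scatter). The estimated value for compound 4 is 1.2 mL/min, within a range from 0.6 mL/min to 2.4 mL/min.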

Compound 4, intrinsic clearance in a liver preparation (reported as CLH), per the amount of preparation that the assay uses: 1.08 mL/min
For compound 4 the middle estimate is 1.1-fold (0.05 log units) above the measured one; measured number inside the range.
By their numbers in this assay, from the lowest: compounds 1, 4, 2 and 3 (each within the scatter of the next, the first and the last beyond it).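

In this assay, for the compounds shown here, the 3-chloro-4-fluorophenyl in place of 3,5-difluorophenyl on the sulfonyl sulfur gives the first reading of a change at this position in isolation: a 1.4-fold lower number from compound 2 to compound 4 (0.15 log units; within the scatter), so this exchange of one halogen-bearing ring for another leaves the two compounds indistinguishable in this measurement. Compound 4 also shares its sulfonyl group with compound 1, which allows the ring on the aromatic carbon to be read on its own, where 4-methoxyphenyl in place of 3-chlorophenyl gives a 1.6-fold higher number from compound 1 to compound 4 (0.21 log units; within the scatter). Each of these two single changes therefore stays within the scatter when taken alone. No supporting data are available to explain where these numbers fall.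

The rings on the sulfonyl sulfur shown here carry only fluorine and chlorine, so it remains open whether an amine or a carboxylic acid on that ring would give a step beyond the scatter in this assay. From the compounds shown here alone, it is also open whether the 3-chloro-4-fluorophenyl would behave the same way alongside the 3-methoxyphenyl group.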